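A few compounds are considered here, and "the series" means these few. Any claim that something is new, unique, unknown or untested is made for them only; others in the source may bear on it.

The study looks at a small set of compounds built on one shared core and tested in a functional assay on HeLa cells (Homo sapiens) for cytotoxicity; a higher number here means a weaker inhibitor, a lower number a stronger inhibitor. Compound 1 `Nc1[nH]nc2nnc(-c3ccco3)cc12` carries a single aromatic substituent on that core. In this assay compound 1 gives > 100000 nM, which is a limit of the assay rather than a measured number. Compound 2 `Nc1[nH]nc2nnc(-c3ccc([N+](=O)[O-])cc3)c(-c3ccc([N+](=O)[O-])cc3)c12` carries two nitrophenyl groups. In this assay compound 2 gives > 100000 nM, again a limit and not a number. Compound 3 `Oc1[nH]nc2nnc(-c3ccccc3)c(-c3ccccc3)c12` carries two phenyl groups and a hydroxy group. In this assay compound 3 gives > 100000 nM, also a limit. Compound 3 therefore stands where all three measured compounds stand: at the limit of > 100000 nM in this assay, at which 3 of the 3 values shown sit. Among the compounds with values here, no step between two measured compounds can be drawn from these data, since none of them yields a number.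

Within the data shown here, compound 4 `O=C(Nc1ccccc1)Nc1[nH]nc2nnc(-c3ccccc3)c(-c3ccccc3)c12` is the one compound not yet measured. It differs from compound 3 in one place: (phenylcarbamoyl)amino in place of hydroxy on an aromatic carbon. Among the measured compounds shown here, with every measured value sitting at the limit, there is no measured step on which to base a direction, so the expected step from compound 3 to compound 4 in this assay, an at least 1.2-fold lower number from compound 3 to compound 4 (0.09 log units; that floor lies within the scatter), is one that most likely stays within the scatter or leaves the value at the limit. Compound 4 is accordingly estimated to give 80000 nM in this assay, within a range from 20000 nM to 200000 nM.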

Compound 4, half-maximal inhibitory concentration: 2930 nM
The estimate for compound 4 lay 27-fold (1.44 log units) above the measured number; the measured number lies below the stated range.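

In this assay, from the compounds shown here alone, replacing hydroxy with (phenylcarbamoyl)amino on an aromatic carbon gives an at least 34-fold lower number from compound 3 to compound 4 (1.53 log units; beyond the scatter), which shows that a change at this one place can take the shared core well clear of the scatter, and that the true size of the step stays open on its far side, since only a floor can be given for it. Compound 4 is the only one of the four shown that yields a number rather than a limit: the limit of > 100000 nM in this assay, at which 3 of the 4 values shown sit. The entering group brings 10 heavy atoms, with one six-membered aromatic ring of carbon only and 2 hydrogen-bond donors, in place of a single oxygen, and this one step cannot separate what each of those parts contributes.

The compounds shown leave open whether a plain amine at this place, on the two phenyl groups of compound 3, would stay at the limit, and whether an acetamide or a urea ending in a short alkyl chain instead of the phenyl would keep the number of compound 4. They also leave open what a chlorine or methoxy group on that terminal phenyl ring would do.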